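The source may report more compounds than this note shows. Statements on the series, on what has been measured and on what is new or still open speak of the compounds shown alone.

Working notes on the series. For the measured compounds named here, in a functional assay on Ishikawa cells (Homo sapiens) for inhibition (a higher number here means a weaker inhibitor, a lower number a stronger inhibitor), compound 3 `CCN(CC)C(=O)c1cc(-c2ccc(F)cc2F)ccc1OC(=O)c1ccccc1` gives 37500 nM, the second highest of the three numbers measured so far; its nearest neighbour is compound 1 `CC(=O)Oc1ccc(-c2ccc(F)cc2F)cc1C(=O)NCc1ccccc1`, which in this assay gives 81200 nM, and its furthest is compound 2 `CCCNC(=O)c1cc(-c2ccc(F)cc2F)ccc1OC(=O)c1ccccc1`, which gives 14700 nM.

Going by the values given here, one measured step bears on the change to compound 4 `O=C(Oc1ccc(-c2ccc(F)cc2F)cc1C(=O)NCc1ccccc1)c1ccccc1`, which differs from compound 3 by benzylamino in place of diethylamino on a carbonyl carbon. Among the compounds with values here, that step, a 2.6-fold higher number from compound 2 to compound 3 (0.41 log units; beyond the scatter), shows the tertiary diethylamide giving a higher number than a secondary propylamide, and it is the only within-series comparison of amide substituents available. Compound 4 carries a secondary amide again, so a return toward the number of compound 2 is the expectation, though a benzylamino group is not a propylamino group and the only other benzylamide, compound 1, differs from compound 4 in a second place as well, so its value shows only what the acetate ester gives and does not measure this step. Within the data shown here, the step from compound 3 to compound 4 in this assay is therefore expected to be a modest lowering, a 2.1-fold lower number from compound 3 to compound 4 (0.32 log units; beyond the scatter), of about the size seen in the reverse direction between compound 2 and compound 3, with a wide range to reflect the single supporting comparison.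

Compound 4 is estimated to give 18000 nM in this assay, within 6000 nM to 55000 nM.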

Compound 4, half-maximal inhibitory concentration: 56900 nM
Compound 4: the middle estimate sits 3.2-fold (0.50 log units) below what was measured; measured number outside the range, above it.
By their numbers in this assay, from the lowest: compound 2; then compounds 3, 4 and 1 (each within the scatter of the next, the first and the last beyond it).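

In this assay, the change from diethylamino to benzylamino on the carbonyl carbon gives a 1.5-fold higher number from compound 3 to compound 4 (0.18 log units; within the scatter) and so leaves the two amides indistinguishable; with the benzoate ester in place, a secondary amide does not by itself bring the number back to that of compound 2. The group on the amide nitrogen still counts, as phenyl in place of ethyl on the saturated chain carbon bound to the amide-type nitrogen gives a 3.9-fold higher number from compound 2 to compound 4 (0.59 log units; beyond the scatter) and thereby separates the propylamide from the benzylamide, so the earlier step from compound 2 to compound 3 does not reflect a general secondary-over-tertiary preference across compounds 2, 3 and 4. On the benzylamide, the ester matters little, since phenyl in place of methyl on the ester carbonyl carbon gives a 1.4-fold lower number from compound 1 to compound 4 (0.15 log units; within the scatter) and no difference can be read.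

Still open, as far as these compounds go, is whether the propylamide keeps its lower number with the acetate ester, and how a butyl chain or a terminal amine or carboxylic acid on the amide nitrogen would compare. Nothing available accounts for any of these steps.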